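Acetamido in place of nitro: an expected step

This account rests on a few compounds, and the source may have more. Where it says the series, first, only, none or still open, it means among the compounds named here.

Compound 1 `Cc1ccc(NC(=O)NCCCCC(c2ccc(F)cc2)c2ccc(F)cc2)cc1`: > 20000 nM (a limit)
Compound 2 `O=C(NCCCCC(c1ccc(F)cc1)c1ccc(F)cc1)Nc1ccc(Cl)c([N+](=O)[O-])c1`: 4060 nM

Within the data shown here, in a functional assay on MDA-MB-231 cells (Homo sapiens) for cytotoxicity, read by MTT assay, with a stated time of 48 h (on this read-out higher numbers stand for weaker inhibition and lower numbers for stronger inhibition), compound 2 gives 4060 nM, the only actual number so far. For compound 1 the reading > 20000 nM is a limit. Compound 3 `CC(=O)Nc1cc(NC(=O)NCCCCC(c2ccc(F)cc2)c2ccc(F)cc2)ccc1Cl` carries acetamido in place of nitro on an aromatic carbon, ortho to a chloro group: acetamido in place of nitro on an aromatic carbon. Among the measured compounds shown here, one measured step bears on this, an at least 4.9-fold lower number from compound 1 to compound 2 (0.69 log units; beyond the scatter), and it brought in the nitro together with the chloro. Part of that gain may therefore be lost in this assay. The expected change is a 2.2-fold higher number from compound 2 to compound 3 (0.35 log units; beyond the scatter). For compound 3 the estimated value is 9000 nM, with an expected range of 3000 nM to 25000 nM.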

Compound 3, half-maximal inhibitory concentration: 9120 nM
For compound 3 the middle estimate is 1.0-fold (0.01 log units) below the measured one, and the stated range covers the measured number.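

Acetamido in place of nitro, ortho to a chloro group, moves the reading in this assay on its own (a 2.2-fold higher number from compound 2 to compound 3 (0.35 log units; beyond the scatter)), which the earlier step, where nitro and chloro entered together, could not show. Not all of the gain over the 4-methylphenyl compound is lost, however (an at least 2.1-fold lower number from compound 1 to compound 3 (0.34 log units; beyond the scatter)). That second comparison rests on compound 1, whose reading is a limit: the limit of > 20000 nM in this assay, at which 1 of the 3 values shown sits.

The compounds shown leave open how a free amine at this position would read. They also leave open how much of the remaining gain belongs to the chloro group alone.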